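The compounds below may be only part of what the source reports. "The series", "measured", "known", "first", "only" and "open" are said of these compounds alone.

Measured compounds:
compound 1 `Cc1cc(Nc2nc(NCc3ccc(F)cc3F)nc3cc(Cl)ccc23)n[nH]1` gives 23 nM in an assay for inhibition of NT-3 growth factor receptor (Homo sapiens), read by HTRF, with a stated time of 40 min, in the presence of a further agent that is not named here; on this read-out lower numbers stand for stronger inhibition and higher numbers for weaker inhibition
compound 2 `Cc1ccc2c(Nc3cc(C)[nH]n3)nc(NCc3ccc(F)cc3F)nc2c1` gives 12 nM in this assay
compound 3 `Cc1cc(Nc2nc(NCc3ccc(F)cc3F)nc3cc(C(F)(F)F)ccc23)n[nH]1` not yet measured

Among the compounds with values here, compound 2 has the lower of the two numbers in this assay, but the only step at this position, a 1.9-fold lower number from compound 1 to compound 2 (0.28 log units; within the scatter), lies within the scatter, so compound 1 and compound 2 cannot be ordered. The change to compound 3 is trifluoromethyl in place of methyl on an aromatic carbon. That single step is the only measured one bearing on the change, and it gives no basis for a shift beyond the scatter in this assay. The step expected is a 1.7-fold higher number from compound 2 to compound 3 (0.22 log units; within the scatter). Compound 3 is therefore estimated at 20 nM, with a range from 8 nM to 50 nM.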

Compound 3, half-maximal inhibitory concentration: 4.5 nM
Compound 3: middle estimate off by 4.4-fold (0.65 log units), on the high side; measured number outside the range, below it.
By their numbers in this assay, from the lowest: compound 3; then compounds 2 and 1 (each within the scatter of the next).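

In this assay this aromatic carbon proves sensitive to its substituent: trifluoromethyl gives a 2.7-fold lower number from compound 2 to compound 3 (0.43 log units; beyond the scatter) and a 5.1-fold lower number from compound 1 to compound 3 (0.71 log units; beyond the scatter) whereas methyl and chloro could not be ordered. Within the data shown here, compound 3 is therefore the one compound here set apart from both others by steps beyond the scatter, though each step is modest. Nothing available explains this difference.

Still open, going by these compounds, is how a nitrile, a methoxy group or an amine on this carbon would compare with trifluoromethyl. Also open, on these data alone, is whether the step persists when the core changes elsewhere.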